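Changing the methoxy pattern on the shared core

This account rests on a few compounds, and the source may have more. Where it says the series, first, only, none or still open, it means among the compounds named here.

Measured so far in a functional assay on MCF7 cells (Homo sapiens) for inhibition, read by MTT assay, with a stated time of 48 h (on this read-out higher numbers stand for weaker inhibition and lower numbers for stronger inhibition), are these compounds:
- compound 1 `Brc1ccc2[nH]cc(C(c3ccccc3)c3c[nH]c4ccc(Br)cc34)c2c1` gives 5500 nM as its value
- compound 2 `COc1ccc(C(c2c[nH]c3ccc(Br)cc23)c2c[nH]c3ccc(Br)cc23)cc1` gives 2300 nM as its value

Among the measured compounds shown here, of these two numbers, compound 2 holds the lower one, and compound 1 is its only neighbour. Compound 3 `COc1cccc(C(c2c[nH]c3ccc(Br)cc23)c2c[nH]c3ccc(Br)cc23)c1OC` differs from compound 2 by 2,3-dimethoxyphenyl in place of 4-methoxyphenyl on a saturated chain carbon bound to two aromatic carbons on a saturated chain carbon bound to two aromatic carbons. For the measured compounds named here, only one measured step bears on this change, methoxy in place of hydrogen on an aromatic carbon, and the modest 2.4-fold lower number from compound 1 to compound 2 (0.38 log units; beyond the scatter) is all there is to go on. Going by the values given here, no measured step shows one methoxy pattern exchanged for another, so only a small change is expected, with no firm direction. The expected step is a 1.2-fold lower number from compound 2 to compound 3 (0.06 log units; within the scatter) and no larger. Compound 3 is estimated at 2000 nM in this assay with an expected range from 700 nM to 6000 nM around it.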

Compound 3, half-maximal inhibitory concentration: 89000 nM
Compound 3: middle estimate off by 45-fold (1.65 log units), on the low side; measured number outside the range, above it.
By their numbers in this assay, from the lowest: compound 2; then compound 1; then compound 3.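

In this assay, the earlier compounds had shown only a modest response to a methoxy group at the saturated chain carbon bound to two aromatic carbons, but the methoxy pattern proves far more decisive here: 2,3-dimethoxyphenyl in place of 4-methoxyphenyl gives a 39-fold higher number from compound 2 to compound 3 (1.59 log units; beyond the scatter) as the step. The result is more than the loss of a small gain, since 2,3-dimethoxyphenyl in place of phenyl also gives a 16-fold higher number from compound 1 to compound 3 (1.21 log units; beyond the scatter) as its step. Adding methoxy to this phenyl ring therefore does not move the number in one direction across these compounds, and nothing available explains the reversal. The compounds shown leave open whether the large step belongs to 2,3-dimethoxyphenyl as a whole or to one of its two methoxy groups, as neither 2-methoxyphenyl nor 3-methoxyphenyl stands among them. Going by these compounds, how a hydroxy group, a chlorine or an amine on this ring would read also remains open.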